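A few compounds are considered here, and "the series" means these few. Any claim that something is new, unique, unknown or untested is made for them only; others in the source may bear on it.

Compounds with numbers in hand:

Compound 1, `CC[C@@H]1C[C@H](CC)CN(CCCNC(=O)C2CCN(Cc3nc(-c4ccccc4C)oc3C)CC2)C1`: 3470 nM
Compound 2, `Cc1ccccc1-c1nc(CN2CCC(C(=O)NCCCN3CC(C)(C)CC(C)(C)C3)CC2)c(C)o1`: 4380 nM
Compound 3, `Cc1oc(-c2ccc(Cl)cc2)nc1CN1CCC(C(=O)NCCCN2C[C@H](C)C[C@H](C)C2)CC1`: 11500 nM

All three numbers come from an ADME assay on Huh7.5.1 cells (Homo sapiens) for cytotoxicity, read by ATP content, with a stated time of 48 h; on this read-out lower numbers stand for higher toxicity in this test and higher numbers for lower toxicity in this test. Compound 3 gives the highest number of the three, and its gaps to compound 2 and to compound 1 both lie beyond the scatter, so compound 3 is the least toxic of the set in this assay. Among the compounds with values here, the one single-site step measured so far, a 1.3-fold higher number from compound 1 to compound 2 (0.10 log units; within the scatter), swaps one saturated ring for another on the chain carbon three bonds from the amide-type nitrogen and leaves the number essentially unchanged.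

Compound 4, `Cc1cccc(-c2nc(CN3CCC(C(=O)NCCCN4C[C@H](C)C[C@H](C)C4)CC3)c(C)o2)c1`, differs from compound 3 in one place: 3-methylphenyl in place of 4-chlorophenyl on an aromatic carbon. Within the data shown here, no measured step touches the aryl group on the five-membered ring, so no step bears directly on this change; compound 2 carries a different aryl group but also a different saturated ring, so its gap to compound 3 cannot be split. Among the measured compounds shown here, with nothing pointing either way, and the only measured step being within the scatter, the expectation is a step of no more than scatter size, a 1.3-fold lower number from compound 3 to compound 4 (0.11 log units; within the scatter), with the number for compound 4 estimated at 9000 nM, between 4000 nM and 20000 nM.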

Compound 4, half-maximal cytotoxic concentration: 16500 nM
Beside the measured number, compound 4's estimate is 1.8-fold (0.26 log units) below it, within the range that was stated.
By their numbers in this assay, from the lowest: compounds 1 and 2 (each within the scatter of the next); then compounds 3 and 4 (each within the scatter of the next).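

In this assay, 3-methylphenyl in place of 4-chlorophenyl, on an aromatic carbon of the five-membered aromatic ring with 1 nitrogen and 1 oxygen, gives a 1.4-fold higher number from compound 3 to compound 4 (0.16 log units; within the scatter). Within the data shown here, this is the first measured step at this aryl group, and it shows that this exchange, which removes the chlorine and also moves the substituent to another place on the phenyl ring, leaves the number within the scatter. The step is thus of the same standing as the one on the saturated ring, a 1.3-fold higher number from compound 1 to compound 2 (0.10 log units; within the scatter), and nothing measured here offers an explanation for either result.

Because the pair changes the atom and its place on the phenyl ring together, the two contributions cannot be separated, and 4-methylphenyl or 3-chlorophenyl at this carbon would be needed to tell them apart. From the compounds shown here alone, also open in this assay is whether the number stays in this range with a pyridyl ring or a phenyl ring carrying a carboxylic acid at this carbon, with the saturated ring of compound 4 kept in place.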